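The compounds below may be only part of what the source reports. "The series", "measured", "known", "first", "only" and "open" are said of these compounds alone.

Working notes on the series. Compound 1 `C=CC(=O)Nc1ccc(Cn2nc(-c3ccc(Oc4ccccc4)cc3)cc2C(=O)O)cc1` is run in a functional assay on Maver1 cells (Homo sapiens) for inhibition, read by luminescence and CellTiter-Glo, with a stated time of 72 h; on this read-out lower numbers stand for stronger inhibition and higher numbers for weaker inhibition. In this assay compound 1 gives only a limit of the assay, > 60000 nM. Compound 2 `C/C=C/C(=O)N1CCCC(n2nc(-c3ccc(Oc4ccccc4)cc3)cc2C(=O)O)C1` likewise returns a limit in this assay, > 60000 nM. Among the compounds with values here, compound 3 `C=CC(=O)Nc1cccc(Cn2nc(-c3ccc(Oc4ccccc4)cc3)cc2C(=O)O)c1` is the one member with a number in this assay, giving 37400 nM. The step of an at least 1.6-fold lower number from compound 1 to compound 3 (0.20 log units; that floor lies within the scatter) changes 3-((vinylcarbonyl)amino)phenyl for 4-((vinylcarbonyl)amino)phenyl and does not clear the scatter. Compound 1 therefore stands at the limit of > 60000 nM in this assay, at which 2 of the 3 values shown sit, with no numerical value of its own.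

Compound 4 `C=CC(=O)Nc1ccc(Cn2nc(-c3ccc(Oc4ccccc4)cc3)cc2C(=O)OCC)cc1` differs from compound 1 by ethyl in place of hydrogen on an oxygen next to a carbonyl group, carboxy going to ethoxycarbonyl. Within the data shown here, no measured step touches this oxygen; the single measured step of an at least 1.6-fold lower number from compound 1 to compound 3 (0.20 log units; that floor lies within the scatter) concerns a different part of the structure and gives no guide. The expectation rests on compound 1 alone.

Compound 4 is expected to remain near the limit in this assay, estimated at 60000 nM with a range from 20000 nM to 200000 nM. The step of a number no higher from compound 1 to compound 4 (the limit leaves the size open) is expected to stay within the scatter.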

Compound 4, half-maximal inhibitory concentration: 13300 nM
The estimate for compound 4 lay 4.5-fold (0.65 log units) above the measured number; measured number outside the range, below it.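

With ethyl in place of hydrogen on this oxygen, the series shows an at least 4.5-fold lower number from compound 1 to compound 4 (0.65 log units; beyond the scatter) in this assay and so gains its first step that clears the scatter. The earlier step, which changed 4-((vinylcarbonyl)amino)phenyl to 3-((vinylcarbonyl)amino)phenyl, did not clear it, so the carboxy group is the only place shown where a change is readable. Compound 1 has only a limit of the assay and no number of its own, so the step has a floor and its full size stays open: the limit of > 60000 nM in this assay, at which 2 of the 4 values shown sit.

On these data alone, whether ethoxycarbonyl gives a similar step with the 3-((vinylcarbonyl)amino)phenyl group of compound 3 remains open. Also open, as far as these compounds go, is how methoxycarbonyl, an ester with a longer chain or a primary carboxamide would read in place of carboxy.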